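The compounds below may be only part of what the source reports. "The series", "measured", "known", "first", "only" and "open" are said of these compounds alone.

Measured in an assay for inhibition of Alpha amylase (Homo sapiens), with a stated time of 10 min; on this read-out higher numbers stand for weaker inhibition and lower numbers for stronger inhibition:

Compound 1, `COc1cccc(-c2nc3ccccc3[nH]2)c1Cl`: 2740 nM
Compound 2, `COc1cc(Br)c(-c2nc3ccccc3[nH]2)cc1OC`: 1510 nM
Compound 3, `COc1cccc(-c2nc3cc(F)ccc3[nH]2)c1Cl`: 2620 nM

Compound 3 arises from compound 1 by one change, (fluoro in place of hydrogen on an aromatic carbon), and in this assay the step is a 1.0-fold lower number from compound 1 to compound 3 (0.02 log units; within the scatter). Compound 2 carries a core that differs from that of compound 1 in more than one place; the difference between the two cores is not broken down here. Compound 2 gives a number that lies within the scatter of both compound 1 and compound 3, so no order among the three can be claimed.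

Compound 4, `COc1cc(Br)c(-c2nc3cc(F)ccc3[nH]2)cc1OC`, is not yet measured. It arises from compound 2 by the same change, (fluoro in place of hydrogen on an aromatic carbon), the second time this change occurs among these compounds. The expectation for compound 4 is a step of a 1.0-fold lower number from compound 2 to compound 4 (0.00 log units; within the scatter), which rests on the near-unchanged result of a 1.0-fold lower number from compound 1 to compound 3 (0.02 log units; within the scatter). Compound 4 is therefore estimated at 1500 nM, with a likely range from 750 nM to 3000 nM.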

Compound 4, half-maximal inhibitory concentration: 1570 nM
For compound 4 the middle estimate is 1.0-fold (0.02 log units) below the measured one, within the range that was stated.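

In this assay, putting fluoro in place of hydrogen on an aromatic carbon of the core of compound 2 gives a small step (a 1.0-fold higher number from compound 2 to compound 4 (0.02 log units; within the scatter)). The two steps for this change agree across the two cores: the same change on two cores in this assay, a 1.0-fold lower number (0.02 log units; within the scatter) from compound 1 to compound 3 and a 1.0-fold higher number (0.02 log units; within the scatter) from compound 2 to compound 4, 1.1-fold (0.04 log units) apart, within the scatter of two such steps. This shows that on these two cores the change leaves the number within the scatter, but it does not show that the same would hold on other cores or at other places, and with no step beyond the scatter it shows no effect of fluoro that could be carried over.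

The compounds shown leave open what a different group in the same place would do, such as an amine, a carboxylic acid or a longer chain. They also leave open whether any such group would move the number beyond the scatter on either core.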